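One Flipped Stereocentre in a Brominated Chain

The source may hold more compounds than are shown below. What is called first, only, known or untested is meant among the compounds shown, and "the series" means these compounds.

Compound 1 `O=C(O)CCC/C=C\C[C@@H]1[C@@H](/C=C/C(O)CCc2cccc(Br)c2)[C@H](O)C[C@@H]1O`: 33 nM; 4.9 nM (2 entries)
Compound 2 `O=C(O)CCC/C=C\C[C@@H]1[C@@H](/C=C/[C@H](O)CCc2ccc(Br)cc2)[C@H](O)C[C@@H]1O`: 2100 nM

Going by the values given here, in a functional assay (Sphincter muscle) with Felis catus as the target (on this read-out higher numbers stand for an effect only at larger amounts of compound and lower numbers for an effect already at smaller amounts), compound 2 gives 2100 nM, the only single number it has, as one further entry gave none. Compound 1 gives 33 nM; 4.9 nM (2 entries), so compound 2 needs far more material for the same effect. Compound 3 `O=C(O)CCC/C=C\C[C@@H]1[C@@H](/C=C/[C@@H](O)CCc2ccc(Br)cc2)[C@H](O)C[C@@H]1O` has not been measured. It is built from the same parts as compound 2: the two compounds have the same atoms and bonds and differ only in configuration as drawn: 1 of 7 stereo elements differ; a stereocentre at a saturated chain carbon is drawn R in compound 2 and S in compound 3.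

Among the compounds with values here, no measured pair shows what this flip does, so any forecast is uncertain. Even so, a large fall in the number is expected, since compound 1 at 33 nM; 4.9 nM (2 entries) shows that this family can act at much smaller amounts. The expected change is a 70-fold lower number from compound 2 to compound 3 (1.85 log units; beyond the scatter). For compound 3 the estimated value is 30 nM, with an expected range from 5 nM to 300 nM.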

Compound 3, half-maximal effective concentration: 35 nM
Beside the measured number, compound 3's estimate is 1.2-fold (0.07 log units) below it, within the range that was stated.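

In this assay the drawing of this saturated chain carbon carries great weight: the flip gives a 60-fold lower number from compound 2 to compound 3 (1.78 log units; beyond the scatter) and so ties the S form directly to an effect at much smaller amounts of compound. The whole step can be laid on this single centre, since nothing enters or leaves: the fact that compounds 2 and 3 differ only in the configuration as drawn. Compound 1 differs from compound 2 in more than one place, so it could only hint that this family can work at small amounts, not show what this centre does.

Still open, from the compounds shown here alone, is whether the same preference for the S form holds when the bromine gives way to another group, such as chlorine or trifluoromethyl. It is also unknown what happens at this centre if a ketone replaces the hydroxyl group, or if a longer chain leads to the ring.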